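The source may report more compounds than this note shows. Statements on the series, on what has been measured and on what is new or still open speak of the compounds shown alone.

Measured so far:
compound 1 `COc1ccc(C(=O)CSc2nc3ccccc3[nH]2)cc1OC`, 19100 nM
compound 2 `O=C(CSc1nc2ccccc2[nH]1)c1ccc(F)cc1`, 78700 nM
compound 3 `COc1ccc(C(=O)CSc2nc3ccccc3[nH]2)c(OC)c1OC`, 18800 nM

All three share the same core and differ only in the substitution of the aryl ketone ring. In a functional assay on HT-29 cells (Homo sapiens) for inhibition, read by WST assay, with a stated time of 48 h (a higher number here means a weaker inhibitor, a lower number a stronger inhibitor), compound 2 gives 78700 nM, the highest of the three numbers; compound 1 and compound 3 sit beyond the scatter below it. Within the data shown here, the one measured step, a 1.0-fold lower number from compound 1 to compound 3 (0.01 log units; within the scatter), concerns a methoxy in place of hydrogen on an aromatic carbon and does not touch the fluoro.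

Compound 4 `O=C(CSc1nc2ccccc2[nH]1)c1ccccc1` is the next case: hydrogen in place of fluoro on an aromatic carbon. Among the measured compounds shown here, no measured step follows the loss of a fluoro, so the direction cannot be read from the series. The values of compound 1 and compound 3 only show that ring substitution can move the number beyond the scatter in this assay. Compound 4 is therefore expected to land close to compound 2, with an estimated step of a 1.3-fold lower number from compound 2 to compound 4 (0.12 log units; within the scatter). The estimate for compound 4 is 60000 nM, within 25000 nM to 150000 nM.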

Compound 4, half-maximal inhibitory concentration: 38500 nM
Compound 4: the middle estimate sits 1.6-fold (0.19 log units) above what was measured, and the stated range covers the measured number.
By their numbers in this assay, from the lowest: compounds 3, 1 and 4 (each within the scatter of the next, the first and the last beyond it); then compound 2.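

In this assay, hydrogen in place of fluoro on an aromatic carbon, para to a large group, gives a 2.0-fold lower number from compound 2 to compound 4 (0.31 log units; beyond the scatter) as a modest step just beyond the scatter. Among these compounds, this is the first single-place change to move the number beyond the scatter, and here the fluoro-bearing compound 2 is the weaker inhibitor of the pair, whereas a 1.0-fold lower number from compound 1 to compound 3 (0.01 log units; within the scatter) stays within it. No measurement shown accounts for the step, so it stands as an observation only.

As far as these compounds go, it remains open whether this step is specific to fluoro or would appear with other groups on the same carbon, such as an amine or a carboxylic acid. Also open, from the compounds shown here alone, is whether the same exchange would give a similar step on a ring that also carries methoxy groups.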